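Aryl hydrazone variation in a semicarbazide series

This account rests on a few compounds, and the source may have more. Where it says the series, first, only, none or still open, it means among the compounds named here.

Compound 1 `CN(C)CCn1cnnc1-c1cc(Oc2ccc(NC(=O)N/N=C/c3c[nH]c4ccccc34)cc2F)ccn1`: 690 nM
Compound 2 `CN(C)CCn1cnnc1-c1cc(Oc2ccc(NC(=O)N/N=C/c3ccccc3)cc2F)ccn1`: 2250 nM
Compound 3 `CN(C)CCn1cnnc1-c1cc(Oc2ccc(NC(=O)N/N=C/c3cccc(Cl)c3Cl)cc2F)ccn1`: 13200 nM

In a functional assay on U-87MG ATCC cells (Homo sapiens) for cytotoxicity, read by MTT assay, with a stated time of 72 h (on this read-out lower numbers stand for stronger inhibition and higher numbers for weaker inhibition), compound 3 stands as the weakest of the three measured compounds. Compound 4 `COc1ccc(/C=N/NC(=O)Nc2ccc(Oc3ccnc(-c4nncn4CCN(C)C)c3)c(F)c2)cc1O` differs from it by 3-hydroxy-4-methoxyphenyl in place of 2,3-dichlorophenyl on a carbon with a double bond to nitrogen. Among the measured compounds shown here, the steps that bear on this change are a 5.9-fold higher number from compound 2 to compound 3 (0.77 log units; beyond the scatter) and a 19-fold higher number from compound 1 to compound 3 (1.28 log units; beyond the scatter), both showing that the 2,3-dichlorophenyl group gives the highest number here. Replacing it with an oxygenated phenyl ring is expected to move back toward the values of compound 2 and compound 1, giving an estimated 5.3-fold lower number from compound 3 to compound 4 (0.72 log units; beyond the scatter). For compound 4 the expected result in this assay is 2500 nM, within a range from 800 nM to 8000 nM.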

Compound 4, half-maximal inhibitory concentration: > 100000 nM
Compound 4 ended at the assay's limit; the forecaster's own chance of this, stated with the estimate: 5%; at least 40-fold (1.60 log units) between middle value and limit.
By their numbers in this assay, from the lowest: compound 1; then compound 2; then compound 3. At a limit, above all of these: compound 4.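

Compound 4 ended at a limit of the assay, so its result is a bound and not a number: the limit of > 100000 nM in this assay, at which 1 of the 4 values shown sits. On the carbon with a double bond to nitrogen, 3-hydroxy-4-methoxyphenyl goes past even 2,3-dichlorophenyl, with an at least 7.5-fold higher number from compound 3 to compound 4 (0.87 log units; beyond the scatter), alongside an at least 44-fold higher number from compound 2 to compound 4 (1.64 log units; beyond the scatter) and an at least 140-fold higher number from compound 1 to compound 4 (2.16 log units; beyond the scatter). Both substituted phenyl rings, in compound 3 and compound 4, thus give higher numbers than the plain phenyl of compound 2, whether the substituents are chlorine or oxygen-bearing groups. The compounds shown leave open whether the hydroxy or the methoxy group alone accounts for this step, as a 3-hydroxyphenyl or a 4-methoxyphenyl would tell. They also leave open how a 4-aminophenyl ring would behave here.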